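This account rests on a few compounds, and the source may have more. Where it says the series, first, only, none or still open, it means among the compounds named here.

Of the compounds shown here, three sharing one core have been measured in an assay on isolated protein for inhibition of sphingosine kinase 2 (Homo sapiens); a higher number here means a weaker inhibitor, a lower number a stronger inhibitor. Compound 1 `N[C@@H](CO)[C@H](O)/C=C/CCCCCCCCc1ccc(I)cc1` gives 5730 nM, compound 2 `N[C@@H](CO)[C@H](O)/C=C/CCCCCCCCCc1ccc(I)cc1` gives 16600 nM, and compound 3 `N[C@@H](CO)[C@H](O)/C=C/CCCCCCCCCCc1ccc(I)cc1` gives 4380 nM. Compound 3 thus holds the lowest of the three numbers, but its gap to compound 1 lies within the scatter, while compound 2 stands clearly higher than both. The step now considered leads to compound 4 `N[C@@H](CO)[C@H](O)/C=C/CCCCCCCCCCCc1ccc(I)cc1`, in which (4-iodobenzyl in place of 4-iodophenyl on a saturated chain carbon, ten or more bonds along the chain from a double-bonded chain carbon). Within the data shown here, two measured steps bear on it, each the same kind of exchange made closer along the chain to the double-bonded chain carbon, and they run in opposite directions: a 2.9-fold higher number from compound 1 to compound 2 (0.46 log units; beyond the scatter) and a 3.8-fold lower number from compound 2 to compound 3 (0.58 log units; beyond the scatter). Both are modest, and together they give no consistent direction. The expected step is a 1.4-fold higher number from compound 3 to compound 4 (0.14 log units; within the scatter), which may stay within the scatter or reach a modest size either way. The estimate for compound 4 in this assay is 6000 nM, within a range of 2500 nM to 15000 nM.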

Compound 4, half-maximal inhibitory concentration: 13300 nM
Compound 4: the middle estimate sits 2.2-fold (0.35 log units) below what was measured; the range from low to high includes it.
By their numbers in this assay, from the lowest: compounds 3 and 1 (each within the scatter of the next); then compounds 4 and 2 (each within the scatter of the next).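

In this assay, the exchange of 4-iodobenzyl for 4-iodophenyl at this position gives a 3.0-fold higher number from compound 3 to compound 4 (0.48 log units; beyond the scatter), so the direction turns once more after a 3.8-fold lower number from compound 2 to compound 3 (0.58 log units; beyond the scatter). The earlier compounds shown here offered only one rise and one fall, whereas the series now alternates from step to step, and none of the four compounds goes against this alternation. The two rises also match closely in size, so the first is no longer an isolated step: the same change on two cores in this assay, a 2.9-fold higher number (0.46 log units; beyond the scatter) from compound 1 to compound 2 and a 3.0-fold higher number (0.48 log units; beyond the scatter) from compound 3 to compound 4, 1.0-fold (0.02 log units) apart, within the scatter of two such steps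

As far as these compounds go, whether the alternation continues with a longer chain remains open, since four compounds cannot show how far it extends. It is also unknown whether it depends on the iodine, as the compounds shown do not say how the series would behave with a bromine or an unsubstituted phenyl in its place.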